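Aminopiperidine in place of hydroxypropylamino on the aryl ring

The source may hold more compounds than are shown below. What is called first, only, known or untested is meant among the compounds shown, and "the series" means these compounds.

Compound 2 `CC(=O)Nc1cc(Nc2cc(NC3CC3)n3ncc(C#N)c3n2)ccc1NCCCO` gives 21 mL.min-1.g-1 in an ADME assay on liver for metabolic stability, with Liver microsome (Homo sapiens) as the target, using microsomes (a lower number here means slower removal, a higher number faster removal of the compound), and stands at the top of the three numbers, with compound 1 `CC(=O)Nc1cccc(Nc2cc(NC3CC3)n3ncc(C#N)c3n2)c1` at 20 mL.min-1.g-1 within the scatter and compound 3 `CC(=O)Nc1cc(Nc2cc(NC3CC3)n3ncc(C#N)c3n2)ccc1N1CC[C@H](N(C)C)C1` at 9 mL.min-1.g-1 clearly lower. The step to compound 4 `CC(=O)Nc1cc(Nc2cc(NC3CC3)n3ncc(C#N)c3n2)ccc1N1CCC[C@H](N)C1` is 3-aminopiperidin-1-yl in place of (3-hydroxypropyl)amino on an aromatic carbon. The measured steps that bear on it both lead to compound 3, the other compound carrying a ring-bound amine: a 2.3-fold lower number from compound 2 to compound 3 (0.37 log units; beyond the scatter) and a 2.2-fold lower number from compound 1 to compound 3 (0.35 log units; beyond the scatter), each modest and beyond the scatter. Going by these compounds, a modest downward step is therefore expected in this assay, though the 3-aminopiperidin-1-yl group itself is untested. The estimate for compound 4 is 12 mL.min-1.g-1, in the range 6 mL.min-1.g-1 to 24 mL.min-1.g-1. This expected value corresponds to a 1.8-fold lower number from compound 2 to compound 4 (0.24 log units; within the scatter).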

Compound 4, intrinsic clearance in microsomes: < 3 mL.min-1.g-1
Compound 4: a limit, no number (the forecaster's own chance of this, stated with the estimate: 5%); at least 4.0-fold (0.60 log units) between middle value and limit.
By their numbers in this assay, from the lowest: compound 3; then compounds 1 and 2 (each within the scatter of the next). At a limit, below all of these: compound 4.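

In this assay, compound 4 reaches a limit of the read-out, not a number: the limit of < 3 mL.min-1.g-1 in this assay, at which 1 of the 4 values shown sits.

On this aromatic carbon, ortho to an acetamido group, 3-aminopiperidin-1-yl gives an at least 7.0-fold lower number from compound 2 to compound 4 (0.84 log units; beyond the scatter) and an at least 6.6-fold lower number from compound 1 to compound 4 (0.82 log units; beyond the scatter), a larger drop than compound 3 had shown. The two ring-bound amines also differ from each other, with an at least 3.0-fold lower number from compound 3 to compound 4 (0.47 log units; beyond the scatter).

The compounds shown do not separate the free amino group from the six-membered ring; 3-aminopyrrolidin-1-yl and 3-(dimethylamino)piperidin-1-yl would address that. Going by these compounds, the full size of each step to compound 4 also remains open.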